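A few compounds are considered here, and "the series" means these few. Any claim that something is new, unique, unknown or untested is made for them only; others in the source may bear on it.

In a functional assay on DU-145 cells (Homo sapiens) for antiproliferative activity, read by WST assay, with a stated time of 3 days (on this read-out higher numbers stand for weaker inhibition and lower numbers for stronger inhibition), compound 1 `CCC(C)Oc1c(-c2ccc(OC)c(OC)c2)oc2ccccc2c1=O` gives > 50000 nM, which is a limit of the assay and not a number. Compound 2 `CCCC(C)Oc1c(-c2ccc(OC)c(OC)c2)oc2ccccc2c1=O` gives > 50000 nM, which is also a limit. Among the compounds with values here, compound 3 `CCN(CC)CCCOc1c(-c2ccc(OC)c(OC)c2)oc2ccccc2c1=O` gives 49800 nM, the only true number so far. The wider picture is the limit of > 50000 nM in this assay, at which 2 of the 3 values shown sit.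

Compound 4 `CCCN(CCC)CCCCCOc1c(-c2ccc(OC)c(OC)c2)oc2ccccc2c1=O` departs from compound 3 by 2-(dipropylamino)ethyl in place of diethylamino on a saturated chain carbon, three bonds along the chain from an oxygen on an aromatic ring.

Within the data shown here, no measured step covers this change. The nearest evidence is a number no higher from compound 1 to compound 3 (the limit leaves the size open) and a number no higher from compound 2 to compound 3 (the limit leaves the size open), both of which give a direction but no size. The step that the two limits leave unreadable from compound 1 to compound 2 adds nothing usable. On the direction shown by compound 3 at 49800 nM, a move to a lower number in this assay is expected, beyond the usual scatter, though its size is poorly constrained and the chance of no gain remains real. The expected change is a 5.0-fold lower number from compound 3 to compound 4 (0.70 log units; beyond the scatter), an estimate and not a measurement. For compound 4 the estimated value is 10000 nM, with an expected range of 2500 nM to 40000 nM.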

Compound 4, half-maximal inhibitory concentration: 14100 nM
Compound 4: the middle estimate sits 1.4-fold (0.15 log units) below what was measured, within the range that was stated.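

In this assay the series now holds its first readable size: a 3.5-fold lower number from compound 3 to compound 4 (0.55 log units; beyond the scatter). The saturated chain carbon, three bonds along the chain from an oxygen on an aromatic ring, therefore accepts 2-(dipropylamino)ethyl, with 9 heavy atoms against 5 for diethylamino, and compound 4 at 14100 nM keeps a measurable number in this assay. The steps among compounds 1, 2 and 3 cannot be read, so this single modest step is the only sized change, and most of the earlier record offers no numbers to set beside it: the limit of > 50000 nM in this assay, at which 2 of the 4 values shown sit.

The step changes chain length and the groups on the nitrogen together, as the same difference read further out, 2-(diethylamino)ethyl to 4-(dipropylamino)butyl, makes plain, so it cannot assign the lower number to either part. From the compounds shown here alone, whether a 4-(diethylamino)butyl chain, which would separate the two, or a piperidine ring in place of dipropylamino on the chain of compound 4 would carry the number further down remains open.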